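What 3,4-dichlorophenyl might do in compound 4

A few compounds are considered here, and "the series" means these few. Any claim that something is new, unique, unknown or untested is made for them only; others in the source may bear on it.

In a functional assay on HeLa cells (Homo sapiens) for cytotoxicity, read by MTT assay, with a stated time of 24 h (a lower number here means a stronger inhibitor, a higher number a weaker inhibitor), compound 1 `COc1cc(/C=C2\CN(C)C/C(=C\c3ccc(F)cc3)C2=O)cc(OC)c1` gives 10200 nM and compound 2 `COc1cc(/C=C2\CN(C)C/C(=C\c3ccc(C#N)cc3)C2=O)cc(OC)c1` gives 3420 nM while compound 3 `COc1cc(/C=C2\CN(C)C/C(=C\c3ccc(F)cc3)C2=O)cc(OC)c1OC` stands at 7250 nM on the same read-out. Methoxy in place of hydrogen on an aromatic carbon accounts for a 1.4-fold lower number from compound 1 to compound 3 (0.15 log units; within the scatter) in this comparison. Compound 3 therefore stands level with compound 1, and its number is higher than that of compound 2.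

Compound 4 `COc1cc(/C=C2\CN(C)C/C(=C\c3ccc(Cl)c(Cl)c3)C2=O)cc(OC)c1OC` has not yet been measured. Compared with compound 3 it changes one group (3,4-dichlorophenyl in place of 4-fluorophenyl on a double-bonded chain carbon bound to a double-bonded ring carbon), with 3,4-dichlorophenyl in place of 4-fluorophenyl on a double-bonded chain carbon bound to a double-bonded ring carbon.

Within the data shown here, only one measured step also removes that fluoro group. Cyano in place of fluoro on an aromatic carbon brought a 3.0-fold lower number from compound 1 to compound 2 (0.47 log units; beyond the scatter) and this counts as a modest step. Chlorine occurs in no measured compound, so this guide is a loose one. A modest move to a lower number is therefore expected in this assay for compound 4, although a result close to compound 3 would be no surprise. That expectation amounts to a 1.9-fold lower number from compound 3 to compound 4 (0.28 log units; within the scatter) as the estimated step. For compound 4 the estimated value is 3800 nM with 1500 nM to 9000 nM as the expected range.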

Compound 4, half-maximal inhibitory concentration: 13500 nM
Beside the measured number, compound 4's estimate is 3.6-fold (0.55 log units) below it; the measured number lies above the stated range.
By their numbers in this assay, from the lowest: compound 2; then compounds 3, 1 and 4 (each within the scatter of the next).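

In this assay the exchange of 4-fluorophenyl for 3,4-dichlorophenyl brings a 1.9-fold higher number from compound 3 to compound 4 (0.27 log units; within the scatter) and so leaves the two compounds indistinguishable on this read-out. Among these compounds, the aromatic ring on a double-bonded chain carbon bound to a double-bonded ring carbon can therefore carry two chlorine atoms in place of one fluorine without a change that stands clear of the scatter, while the only step beyond the scatter at this place remains the cyano exchange, with a 3.0-fold lower number from compound 1 to compound 2 (0.47 log units; beyond the scatter) and a different set of methoxy groups from compound 4, so the lower number seen there does not extend to every replacement of fluoro. No measurement is available that would explain this result.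

The compounds shown leave open what each chlorine contributes alone, since no phenyl ring with a single chlorine appears among them, and whether 3,4-dichlorophenyl would behave the same way with the two methoxy groups of compound 1. They also leave open how this position would respond to a quite different group, such as an amine or a carboxylic acid on the ring.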